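A few compounds are considered here, and "the series" means these few. Any claim that something is new, unique, unknown or untested is made for them only; others in the source may bear on it.

Of the compounds shown here, three of a shared series have been measured in an assay on isolated protein for antagonist activity at Bile acid receptor (Homo sapiens), read by HTRF, with a stated time of 30 min; on this read-out higher numbers stand for weaker inhibition and lower numbers for stronger inhibition. Compound 1 `CCc1cc(CC)c(OCc2ccccc2)cc1OCCCCCC(C)(C)c1nnn[nH]1` gives 3500 nM; compound 2 `CCCCc1cc(CC)c(O)cc1OCCCCCC(C)(C)c1nnn[nH]1` gives 8700 nM; compound 3 `CCCCc1cc(C(C)=O)c(OCc2ccccc2)cc1OCCCCCC(C)(C)c1nnn[nH]1` gives 7800 nM. Among these three numbers compound 3 stands second highest: its nearest neighbour is compound 2, whose number lies within the scatter of that of compound 3, while compound 1 shows a lower number that lies beyond the scatter. Among the compounds with values here, compound 1 and compound 3 differ from each other in more than one place, so no single step between them can be read off.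

Compound 4 `CCc1cc(C(C)=O)c(OCc2ccccc2)cc1OCCCCCC(C)(C)c1nnn[nH]1` is not yet measured. It differs from compound 3 by hydrogen in place of ethyl on a saturated chain carbon, two bonds along the chain from an aromatic carbon. No step between measured compounds that would isolate this change is available, so the expectation rests only on the spread of the three numbers shown. From compound 3 to compound 4 the author expects a step of modest size, a 1.4-fold lower number from compound 3 to compound 4 (0.15 log units; within the scatter), most likely towards a lower number but possibly none beyond the scatter. Compound 4 is therefore estimated at 5500 nM in this assay, with a range from 2500 nM to 12000 nM.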

Compound 4, half-maximal inhibitory concentration: 1100 nM
The estimate for compound 4 lay 5.0-fold (0.70 log units) above the measured number, and the stated range ends above it.
By their numbers in this assay, from the lowest: compound 4; then compound 1; then compounds 3 and 2 (each within the scatter of the next).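

In this assay, within the data shown here, butyl to ethyl, which is hydrogen in place of ethyl on a saturated chain carbon, two bonds along the chain from an aromatic carbon, gives a 7.1-fold lower number from compound 3 to compound 4 (0.85 log units; beyond the scatter) and is the first reading of this position, showing that the number responds to the length of this chain. With that ethyl in place, acetyl in place of ethyl on an aromatic carbon gives a 3.2-fold lower number from compound 1 to compound 4 (0.50 log units; beyond the scatter) and so the aromatic carbon bearing the acetyl is now read as a position in its own right. Nothing available accounts for either step.

Going by these compounds, the shortening is read only with acetyl present, so whether it holds with ethyl on that aromatic carbon stays open. Also open, on these data alone, is how propyl or methyl on the chain would read, and how a carboxylic acid or an amine would read in place of the acetyl.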